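Swapping a fluorinated tail for a branched alkene tail

The compounds below may be only part of what the source reports. "The series", "measured", "known", "first", "only" and "open" are said of these compounds alone.

Among the compounds with values here, compound 1 `O=C(NNc1nncc2ccccc12)C1CC1c1ccc(OCC(F)(F)F)cc1` is the only compound with a measured number. In a functional assay on MCF7 cells (Homo sapiens) for inhibition, read by MTT assay, with a stated time of 72 h (a lower number here means a stronger inhibitor, a higher number a weaker inhibitor), compound 1 gives 8000 nM. A second compound, compound 2 `CC(C)=CCC/C(C)=C/COc1ccc(C2CC2C(=O)NNC(=O)c2ccncc2)cc1`, belongs to the same set but carries a different core on one side, and in this assay compound 2 gives "not determined" (no result reported), so it offers no number to compare against.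

Compound 3 `CC(C)=CCOc1ccc(C2CC2C(=O)NNc2nncc3ccccc23)cc1` keeps the core of compound 1 and changes only the tail on the aromatic oxygen: 2-methylprop-1-en-1-yl in place of trifluoromethyl on a saturated chain carbon bound to an oxygen on an aromatic ring. Within the data shown here, no pair of measured compounds shows what this kind of exchange does here, so there is no measured step to lean on.

With nothing beyond compound 1 to anchor a direction, the step of a 1.3-fold lower number from compound 1 to compound 3 (0.12 log units; within the scatter) is expected to stay small, within the ordinary scatter, rather than move clearly stronger or weaker. On that basis compound 3 is expected to give about 6000 nM in this assay, with a likely range from 2000 nM to 20000 nM.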

Compound 3, half-maximal inhibitory concentration: 69000 nM
Compound 3: middle estimate off by 12-fold (1.06 log units), on the low side; measured number above the stated range.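

Within the data shown here, this is the first measured exchange at this position, and it shows that the tail on the aromatic oxygen is not a neutral place to make changes in this assay. Putting 2-methylprop-1-en-1-yl in place of trifluoromethyl brings an 8.6-fold higher number from compound 1 to compound 3 (0.94 log units; beyond the scatter), which means a weaker inhibitor by a margin beyond the usual scatter. The two groups have the same number of heavy atoms and neither has a hydrogen-bond donor or acceptor, so those counts do not separate them, and no measurement shown here gives a reason for the step.

The exchange changes several things at once, removing the fluorine atoms, adding a double bond and adding a branch, so this single pair cannot show which of them goes with the higher number. Among these compounds, a saturated 3-methylbutyl tail or a plain ethyl tail on the same oxygen would help pull these apart, and whether the same exchange behaves alike on the other core, the one in compound 2, remains open.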